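Cytotoxicity notes: 4-chlorophenyl to 4-iodophenyl

The source may hold more compounds than are shown below. What is called first, only, known or untested is meant among the compounds shown, and "the series" means these compounds.

In an ADME assay on WI-38 cells (Homo sapiens) for cytotoxicity, read by MTT assay, with a stated time of 72 h (on this read-out lower numbers stand for stronger inhibition and higher numbers for weaker inhibition), compound 3 `O=C(CCc1cccc2c1B(O)OC2)Nc1ccc(Cl)cc1` reads > 100000 nM, which is a limit. Compound 1 `CCNC(=O)CCc1cccc2c1B(O)OC2` reads > 100000 nM, also a limit. Compound 2 `O=C(CCc1cccc2c1B(O)OC2)Nc1ccccc1` gives 30000 nM. The series thus shows (the limit of > 100000 nM in this assay, at which 2 of the 3 values shown sit).

Compound 4 `O=C(CCc1cccc2c1B(O)OC2)Nc1ccc(I)cc1` has iodo in place of chloro on an aromatic carbon, para to a large group: iodo in place of chloro on an aromatic carbon.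

The closest measured change is chloro in place of hydrogen, an at least 3.3-fold higher number from compound 2 to compound 3 (0.52 log units; beyond the scatter). The other bearing steps are an at least 3.3-fold lower number from compound 1 to compound 2 (0.52 log units; beyond the scatter) and a step that the two limits leave unreadable from compound 1 to compound 3. Within the data shown here, no measured step exchanges one halogen for another, so no clear direction is expected, and any change should be small. The expected change is an at least 1.1-fold lower number from compound 3 to compound 4 (0.04 log units; that floor lies within the scatter). For compound 4 the estimate is 90000 nM, with an expected range of 30000 nM to 200000 nM.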

Compound 4, half-maximal inhibitory concentration: 49000 nM
Estimate against measurement, compound 4: 1.8-fold (0.26 log units) above; low and high end bracket the measured number.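

In this assay, among these compounds, iodo in place of chloro at this position gives an at least 2.0-fold lower number from compound 3 to compound 4 (0.30 log units; that floor lies within the scatter), the first step that exchanges one halogen for another. Iodo in place of hydrogen gives a 1.6-fold higher number from compound 2 to compound 4 (0.21 log units; within the scatter), so iodo is not told apart from hydrogen here, whereas chloro did stand apart from hydrogen. The change from the ethyl amide gives an at least 2.0-fold lower number from compound 1 to compound 4 (0.30 log units; that floor lies within the scatter), and this step and the halogen exchange keep only a floor for their size because of the assay ceiling: the limit of > 100000 nM in this assay, at which 2 of the 4 values shown sit.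

Still open, as far as these compounds go, is whether bromo or an amine in the same place reads with iodo or with chloro.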